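Moving the Fluorine on the Benzoyl Group of Compound 2

The compounds below may be only part of what the source reports. "The series", "measured", "known", "first", "only" and "open" are said of these compounds alone.

Compound 1 `O=C(c1cccc(F)c1)N1CC(c2nc(-c3cccc(Cl)c3)no2)C1`: 780 nM in an assay on HEK293 cells for negative allosteric modulation of metabotropic glutamate receptor 5 (Homo sapiens), read by FLIPR; on this read-out lower numbers stand for stronger inhibition and higher numbers for weaker inhibition
Compound 2 `Cc1cccc(-c2noc(C3CN(C(=O)c4ccccc4F)C3)n2)c1`: 1400 nM in this assay
Compound 3 `O=C(c1ccccc1F)N1CC(c2nc(-c3cccc(Cl)c3)no2)C1`: 670 nM in this assay

Compound 2 has the highest of the three numbers in this assay; its gap to compound 1 lies within the scatter, while the step of a 2.1-fold lower number from compound 2 to compound 3 (0.32 log units; beyond the scatter) lies beyond it. Compound 4 `Cc1cccc(-c2noc(C3CN(C(=O)c4cccc(F)c4)C3)n2)c1` differs from compound 2 by 3-fluorophenyl in place of 2-fluorophenyl on a carbonyl carbon. Among the compounds with values here, the one measured step that bears on this change is a 1.2-fold lower number from compound 1 to compound 3 (0.07 log units; within the scatter), the same exchange run the other way, and it stayed within the scatter. The step of a 1.1-fold higher number from compound 2 to compound 4 (0.06 log units; within the scatter) that is expected here should therefore also stay within the scatter, leaning if anything toward a slightly higher number. The value estimated for compound 4 in this assay is 1600 nM, ranging from 800 nM to 3200 nM.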

Compound 4, half-maximal inhibitory concentration: 2100 nM
The estimate for compound 4 lay 1.3-fold (0.12 log units) below the measured number; the measured number falls inside the stated range.
By their numbers in this assay, from the lowest: compounds 3, 1, 2 and 4 (each within the scatter of the next, the first and the last beyond it).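

The fluorine exchange can now be read on a second core, where the step is a 1.5-fold higher number from compound 2 to compound 4 (0.18 log units; within the scatter), so the shift from 2-fluorophenyl to 3-fluorophenyl stays within the scatter on both the chloro and the methyl cores: the same change on two cores in this assay, a 1.2-fold lower number (0.07 log units; within the scatter) from compound 1 to compound 3 and a 1.5-fold lower number (0.18 log units; within the scatter) from compound 4 to compound 2, 1.3-fold (0.11 log units) apart, within the scatter of two such steps

The exchange of chloro and methyl on the aromatic carbon also repeats with the 3-fluorophenyl group in place, as a 2.7-fold higher number from compound 1 to compound 4 (0.43 log units; beyond the scatter), and it agrees with the earlier step: the same change on two cores in this assay, a 2.1-fold lower number (0.32 log units; beyond the scatter) from compound 2 to compound 3 and a 2.7-fold lower number (0.43 log units; beyond the scatter) from compound 4 to compound 1, 1.3-fold (0.11 log units) apart, within the scatter of two such steps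

The compounds shown leave open how an unsubstituted phenyl on the carbonyl carbon would read in this assay. They also leave open how a methoxy or a bromo on the aromatic carbon would compare with chloro.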